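Notes on the 2-methoxyphenyl analogue of compound 2

A few compounds are considered here, and "the series" means these few. Any claim that something is new, unique, unknown or untested is made for them only; others in the source may bear on it.

The series shares one core with two arylidene arms. Compound 1 `C=CCn1c(=O)/c(=C\c2cccc(Cl)c2)[nH]c(=O)/c1=C\c1ccccc1OC` gives 4900 nM in a functional assay on MOLT-4 cells (Homo sapiens) for cytotoxicity, read by CCK-8 assay, with a stated time of 72 h; on this read-out lower numbers stand for stronger inhibition and higher numbers for weaker inhibition. Compound 2 `C=CCn1c(=O)/c(=C\c2cccc(F)c2)[nH]c(=O)/c1=C\c1ccccc1OC` gives 6500 nM in this assay. Compound 3 `C=CCn1c(=O)/c(=C\c2cc(Br)ccc2F)[nH]c(=O)/c1=C\c1ccccc1OC` gives 12900 nM in this assay. Compound 2 holds the second highest of the three numbers; its nearest neighbour is compound 1, its furthest compound 3, and both gaps fall within the scatter. The halogen swap shows a 1.3-fold higher number from compound 1 to compound 2 (0.12 log units; within the scatter). Enlarging the arm gives a 2.0-fold higher number from compound 2 to compound 3 (0.30 log units; within the scatter), and from the other side a 2.6-fold higher number from compound 1 to compound 3 (0.42 log units; beyond the scatter), the only step here that reaches beyond the scatter.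

The next change is 2-methoxyphenyl in place of 3-fluorophenyl on a double-bonded chain carbon bound to an aromatic carbon, giving compound 4 `C=CCn1c(=O)/c(=C\c2ccccc2OC)[nH]c(=O)/c1=C\c1ccccc1OC`, in which both arms carry the same 2-methoxyphenyl. For the measured compounds named here, no measured step covers a move from a halophenyl to a methoxyphenyl on this arm; the three steps at hand stay within or just beyond the scatter, so the arm has so far tolerated variation without large shifts. A step no larger than the scatter is therefore expected in this assay, with no direction favoured, the expected step being a 1.1-fold higher number from compound 2 to compound 4 (0.03 log units; within the scatter). Compound 4 is estimated at 7000 nM, with a range from 2500 nM to 20000 nM.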

Compound 4, half-maximal inhibitory concentration: 13100 nM
Compound 4: the middle estimate sits 1.9-fold (0.27 log units) below what was measured, within the range that was stated.
By their numbers in this assay, from the lowest: compounds 1, 2, 3 and 4 (each within the scatter of the next, the first and the last beyond it).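

With the first arm in the series that carries no halogen, this assay still gives a result in the same band as the halophenyl arms: a 2.0-fold higher number from compound 2 to compound 4 (0.30 log units; within the scatter), and a 1.0-fold higher number from compound 3 to compound 4 (0.01 log units; within the scatter), so replacing the halogen with a methoxy group on this arm gives no step beyond the scatter from either of these compounds. Beyond the scatter lies a 2.7-fold higher number from compound 1 to compound 4 (0.43 log units; beyond the scatter), the only such step other than the one that ends at compound 3, so both such steps start at the 3-chlorophenyl arm and end on an arm named with a 2-substituent, although compound 2, with its 3-fluorophenyl arm, lies within the scatter of compounds 3 and 4 and goes against any clean split by substitution site. No measurement on hand bears on why these numbers fall as they do.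

From the compounds shown here alone, whether the methoxy group or its site on the ring matters remains open, and 3-methoxyphenyl on this arm would address that. Also open is how this arm responds to groups of another kind, such as an amine or a carboxylic acid, since every arm shown is a halophenyl or methoxyphenyl.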